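This account rests on a few compounds, and the source may have more. Where it says the series, first, only, none or still open, it means among the compounds named here.

Measured so far:
compound 1, `CC(c1ccc(-c2ccccc2)c(F)c1)c1nnc2n1N=C(c1ccc(Cl)cc1)CS2`: 3900 nM
compound 2, `CC(c1ccc(-c2ccccc2)c(F)c1)c1nnc2n1N=C(c1ccc(Br)cc1)CS2`: 5000 nM

In a functional assay on Huh-7 cells (Homo sapiens) for inhibition, read by sulforhodamine B assay, with a stated time of 72 h (a lower number here means a stronger inhibitor, a higher number a weaker inhibitor), compound 1 gives 3900 nM and compound 2 gives 5000 nM; the step of a 1.3-fold higher number from compound 1 to compound 2 (0.11 log units; within the scatter) leaves the two numbers within the scatter of each other, so compound 2 sits alongside compound 1 rather than apart from it. Compound 3, `Cc1ccc(C2=Nn3c(nnc3C(C)c3ccc(-c4ccccc4)c(F)c3)SC2)cc1`, differs from compound 2 by methyl in place of bromo on an aromatic carbon. Among the compounds with values here, the only measured step at this position, a 1.3-fold higher number from compound 1 to compound 2 (0.11 log units; within the scatter), was small, and nothing measured here speaks for a larger shift from a methyl. Compound 3 is therefore expected to give about 4500 nM, between 2000 nM and 10000 nM, a step of a 1.1-fold lower number from compound 2 to compound 3 (0.05 log units; within the scatter) that is expected to stay within the scatter.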

Compound 3, half-maximal inhibitory concentration: 7200 nM
The estimate for compound 3 lay 1.6-fold (0.20 log units) below the measured number; the range from low to high includes it.
By their numbers in this assay, from the lowest: compounds 1, 2 and 3 (each within the scatter of the next).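

Methyl in place of bromo gives a 1.4-fold higher number from compound 2 to compound 3 (0.16 log units; within the scatter) and methyl in place of chloro gives a 1.8-fold higher number from compound 1 to compound 3 (0.27 log units; within the scatter) in this assay so both steps stay within the scatter. A group other than a halogen has now been seen at this place on the ring, and its number still sits alongside those of the bromo and chloro compounds. Nothing available offers an explanation for this result. Going by these compounds, whether an amine, a carboxylic acid or a longer chain such as propyl at this place would give a step beyond the scatter remains open.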